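This account rests on a few compounds, and the source may have more. Where it says the series, first, only, none or still open, it means among the compounds named here.

Compound 1 `O=C(Cn1c(=O)oc2cc(Cl)ccc21)Nc1ccccc1`: 15.8%
Compound 2 `O=C(Cn1c(=O)oc2cc([N+](=O)[O-])ccc21)Nc1ccccc1`: 18%

In an ADME assay on RAW264.7 cells (Mus musculus) for cytotoxicity, read by MTT assay, with a stated time of 72 h, tested at 50 uM (on this read-out higher numbers stand for a stronger effect at the one concentration tested and lower numbers for a weaker effect), compound 2 stands at the upper of the two numbers, yet the step of a number 2.2 percentage points higher from compound 1 to compound 2 (within the scatter) is within the scatter, so the two compounds cannot be told apart on this read-out. Compound 3 `O=C(Cn1c(=O)oc2ccccc21)Nc1ccccc1` differs from compound 2 in one place: hydrogen in place of nitro on an aromatic carbon. Among the compounds with values here, the only measured step swapped one group for another at this position and stayed within the scatter; no step shows a group removed outright. The step from compound 2 to compound 3 is therefore expected to be a number 4 percentage points lower from compound 2 to compound 3 (within the scatter), none beyond the scatter. Compound 3 is estimated at 14%, ranging from 4% to 26%.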

Compound 3, a percentage reported as inhibition, at one concentration (the size of the read-out at that concentration, not a potency): 35.1%
For compound 3 the middle estimate is 21.1 percentage points below the measured one; measured number outside the range, above it.
By their numbers in this assay, from the lowest: compounds 1 and 2 (each within the scatter of the next); then compound 3.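

In this assay this position proves not to be indifferent: removing the group outright gives a number 17.1 percentage points higher from compound 2 to compound 3 (beyond the scatter) when nitro leaves, and a number 19.3 percentage points higher from compound 1 to compound 3 (beyond the scatter) when chloro leaves. Swapping one of these groups for the other did not separate the compounds, so the clear difference here lies between hydrogen and either group. Nothing shown here explains this difference.

As far as these compounds go, whether an amine or a methoxy group on this aromatic carbon would give a number like that of compound 3, or one like those of compound 1 and compound 2, remains open.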